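The source may report more compounds than this note shows. Statements on the series, on what has been measured and on what is new or still open speak of the compounds shown alone.

Measured in a functional assay on MCF7 cells (Homo sapiens) for inhibition, read by sulforhodamine B assay, with a stated time of 48 h; on this read-out lower numbers stand for stronger inhibition and higher numbers for weaker inhibition:
- Compound 1 `CCNC(=O)Nc1ccc(/C=C/c2cccc(Cl)c2)cc1`: 20000 nM
- Compound 2 `O=C1NCCN1c1ccc(/C=C\c2cccc(Cl)c2)cc1`: 38 nM

Of these two, compound 2 holds the lower number, 38 nM, and so is the stronger inhibitor, by a margin well beyond the usual scatter. Compound 3 `O=C1NCCN1c1ccc(/C=C/c2cccc(Cl)c2)cc1` has not yet been measured. Its relation to compound 2 is a matter of geometry alone (the two compounds have the same atoms and bonds and differ only in configuration as drawn: 1 of 1 stereo elements differ; a double bond is drawn Z in compound 2 and E in compound 3). Within the data shown here, no measured pair shows directly what this switch does. Compound 1, whose double bond is also drawn E, gives 20000 nM in this assay and that single value is the basis for expecting weaker inhibition, though it is thin evidence. The expected change is a large rise in the number, beyond the scatter, with an estimated 260-fold higher number from compound 2 to compound 3 (2.42 log units; beyond the scatter) as the size of the step. For compound 3 the estimated value is 10000 nM with an expected range from 2000 nM to 40000 nM on this measurement.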

Compound 3, half-maximal inhibitory concentration: 20000 nM
Compound 3: middle estimate off by 2.0-fold (0.30 log units), on the low side; the measured number falls inside the stated range.
By their numbers in this assay, from the lowest: compound 2; then compounds 1 and 3 (each within the scatter of the next).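

In this assay, turning the double bond from Z to E, with nothing else altered, gives a 530-fold higher number from compound 2 to compound 3 (2.72 log units; beyond the scatter), so the geometry of this double bond alone can separate a strong inhibitor from a weak one. The gap can be assigned to that switch and to nothing else, and the ground for this is: the fact that compounds 2 and 3 differ only in the configuration as drawn

With the double bond drawn E, the group on the other end of the molecule makes little difference here: 2-oxoimidazolidin-1-yl in place of (ethylcarbamoyl)amino on an aromatic carbon gives no change at the digits printed from compound 1 to compound 3 (within the scatter).

As far as these compounds go, it remains open whether (ethylcarbamoyl)amino would also give a low number with the double bond drawn Z, since that swap has been read only in the E form. Also open, from the compounds shown here alone, is how a methoxy group or an amine in place of the chlorine would fare in the Z form.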